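Replacing the phenoxy group of compound 1 with a spiro lactam

The source may report more compounds than this note shows. Statements on the series, on what has been measured and on what is new or still open speak of the compounds shown alone.

Compound 1, with the structure `Fc1ccc2c(c1CNc1ncc(Oc3ccccc3)c3nncn13)CCO2`, gives 18 mL.min-1.g-1 in an ADME assay on microsomes from liver (Homo sapiens) for metabolic stability, read by LC-MS, using NADPH, with stated times of 5 min and 30 min, tested at 1 uM (on this read-out higher numbers stand for fast clearance and lower numbers for slow clearance), the highest of the two numbers recorded there. Compound 2, with the structure `Cc1ncc(-c2cnc(NCc3c(F)ccc4c3CCO4)c3cn[nH]c(=O)c23)n1C`, gives 10 mL.min-1.g-1 in this assay, and the gap between these two readings lies within the scatter, so no order between them can be claimed.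

Compound 3, with the structure `O=C1CC2(CC2)CN1c1cnc(NCc2c(F)ccc3c2CCO3)n2cnnc12`, has not yet been measured in this assay. It differs from compound 1 at a single point: a group of 8 heavy atoms (6 carbon, 1 nitrogen, 1 oxygen; one three-membered non-aromatic ring of carbon only, one five-membered non-aromatic ring with 1 hetero atom) in place of a group of 7 heavy atoms (6 carbon, 1 oxygen; one six-membered aromatic ring of carbon only), on an aromatic carbon. The group that leaves is the phenoxy; the group that enters sits on an aromatic carbon of the shared core, ortho to a fused ring.

For the measured compounds named here, no step of this kind has been measured here, so the expectation rests only on the two recorded values. Compound 3 is expected to give 9 mL.min-1.g-1 in this assay, between 4 mL.min-1.g-1 and 20 mL.min-1.g-1. This means a step of a 2.0-fold lower number from compound 1 to compound 3 (0.30 log units; within the scatter) is expected, toward slower clearance, of a size that may or may not exceed the scatter.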

Compound 3, intrinsic clearance in microsomes: < 3 mL.min-1.g-1
Compound 3: a limit, no number; the forecaster's own chance of this, stated with the estimate: 10%; at least 3.0-fold (0.47 log units) between middle value and limit.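

At this position, on an aromatic carbon of the shared core, swapping the phenoxy for the spiro lactam gives an at least 6.0-fold lower number from compound 1 to compound 3 (0.77 log units; beyond the scatter) in this assay. For the compounds shown here, the earlier compounds offered no step between compounds differing in one place, so this is the first sign that the group at this position can move intrinsic clearance beyond the scatter. Compound 3 stands at a limit of the assay and not at a number, so only a lower bound on the size of the step can be read: the limit of < 3 mL.min-1.g-1 in this assay, at which 1 of the 3 values shown sits.

On these data alone, it remains open whether a plain pyrrolidinone without the three-membered carbon ring, or an open-chain amide, would give a similar reading at this position. The compounds shown also do not tell which part of the spiro lactam, or the departure of the phenoxy itself, accounts for the step.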